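Nitro for Hydrogen on the Aminothiophene Benzoyl Series

A few compounds are considered here, and "the series" means these few. Any claim that something is new, unique, unknown or untested is made for them only; others in the source may bear on it.

Measured compounds:
compound 1, `Nc1scc(-c2ccccc2)c1C(=O)c1ccccc1`, 48%
compound 2, `Nc1scc(-c2ccccc2)c1C(=O)c1ccc(Cl)cc1`, 64%
compound 3, `Nc1scc(-c2ccc(Cl)cc2)c1C(=O)c1ccc(Cl)cc1`, 50%

In a functional assay on CHO cells for agonist activity at adenosine receptor A1 (Homo sapiens), read by fluorescence and ERK phosphorylation, with stated times of 30 min and 1.5 h, tested at 10 uM (on this read-out higher numbers stand for a stronger effect at the one concentration tested and lower numbers for a weaker effect), compound 2 stands highest of the three numbers: a number 16 percentage points higher from compound 1 to compound 2 (beyond the scatter), and a number 14 percentage points lower from compound 2 to compound 3 (beyond the scatter). Compound 4, `Nc1scc(-c2cccc([N+](=O)[O-])c2)c1C(=O)c1ccc(Cl)cc1`, differs from compound 2 in one place: nitro in place of hydrogen on an aromatic carbon. Among the compounds with values here, no measured step adds a nitro group, so the nearest guide is the step that placed a second chloro on the same ring, a number 14 percentage points lower from compound 2 to compound 3 (beyond the scatter), a modest drop. A modest change in the same direction, or none beyond the scatter, is therefore expected in this assay. Compound 4 is estimated at 55%, between 35% and 75%, which means an expected step of a number 9 percentage points lower from compound 2 to compound 4 (within the scatter).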

Compound 4, a percentage reported as activity, at one concentration (the size of the read-out at that concentration, not a potency): 42%
Beside the measured number, compound 4's estimate is 13 percentage points above it, within the range that was stated.
By their numbers in this assay, from the lowest: compounds 4, 1 and 3 (each within the scatter of the next); then compound 2.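

In this assay, nitro in place of hydrogen on an aromatic carbon, meta to a large group, brings a number 22 percentage points lower from compound 2 to compound 4 (beyond the scatter). This is the second change on this ring to lower the number, after chloro gave a number 14 percentage points lower from compound 2 to compound 3 (beyond the scatter), so among these compounds, the two groups added to the ring of compound 2 both reduce the effect. No measurement here explains the drop.

On these data alone, whether an amine or a carboxylic acid at this place would also lower the number remains open. So does whether a smaller group, such as methyl, would keep the effect of compound 2.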